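The source may hold more compounds than are shown below. What is called first, only, known or untested is meant among the compounds shown, and "the series" means these compounds.

Measured compounds in a functional assay on A549 cells (Homo sapiens) for antiproliferative activity, read by MTT assay, with a stated time of 72 h; on this read-out higher numbers stand for weaker inhibition and lower numbers for stronger inhibition:
compound 1 `NC1=NC2(CCOCC2)N(OCCCOc2ccc(F)cc2)C(N)=N1`: 1060 nM
compound 2 `Cc1ccc(OCCCON2C(N)=NC(N)=NC23CCOCC3)cc1`: 1060 nM
compound 3 `NC1=NC2(CCOCC2)N(OCCCOc2cccc(Cl)c2Cl)C(N)=N1`: 100 nM

Compound 3 gives the lowest number of the three in this assay; the steps of an 11-fold lower number from compound 1 to compound 3 (1.03 log units; beyond the scatter) and an 11-fold lower number from compound 2 to compound 3 (1.03 log units; beyond the scatter) are both large, whereas no change at the digits printed from compound 1 to compound 2 (within the scatter). Compound 4 `NC1=NC2(CCOCC2)N(OCCCOc2ccccc2Br)C(N)=N1` differs from compound 3 as follows: 2-bromophenyl in place of 2,3-dichlorophenyl on an oxygen on a saturated carbon. The two steps that bear on this are those ending at compound 3, where a 2,3-dichlorophenyl replaced a singly substituted phenyl and the number fell sharply. Compound 4 keeps a single halogen on the phenyl, so part of that gain is expected to be given back in this assay, the estimated step being a 3.0-fold higher number from compound 3 to compound 4 (0.48 log units; beyond the scatter). Compound 4 is therefore expected to give about 300 nM, within 120 nM to 800 nM, in this assay.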

Compound 4, half-maximal inhibitory concentration: 160 nM
Beside the measured number, compound 4's estimate is 1.9-fold (0.27 log units) above it, within the range that was stated.
By their numbers in this assay, from the lowest: compounds 3 and 4 (each within the scatter of the next); then compounds 1 and 2 (each within the scatter of the next).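

In this assay, a single halogen on the phenyl is enough at this place: the change to 2-bromophenyl gives a 1.6-fold higher number from compound 3 to compound 4 (0.20 log units; within the scatter) and so the second chlorine of the 2,3-dichlorophenyl is not required. Singly substituted phenyl groups do not all read alike, with a 6.6-fold lower number from compound 1 to compound 4 (0.82 log units; beyond the scatter) and a 6.6-fold lower number from compound 2 to compound 4 (0.82 log units; beyond the scatter) as the steps to the 2-bromophenyl. No measurement shown accounts for these differences. The compounds shown do not separate the identity of the halogen from its place on the phenyl. On these data alone, how 2-chlorophenyl or unsubstituted phenyl would read remains open.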